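The compounds below may be only part of what the source reports. "The series", "measured", "known", "first", "only" and "open" are said of these compounds alone.

Compound 1 `O=C(O)Cc1sc(C(c2ccc(F)cc2)c2ccc(F)cc2)nc1-c1ccnc(N2CCCC2)c1` reaches only the limit > 100000 nM in an in vitro functional assay on HEK285-7 cells for antagonist activity at prostaglandin D2 receptor 2 (Homo sapiens), read by BRET and beta-arrestin recruitment; on this read-out higher numbers stand for weaker inhibition and lower numbers for stronger inhibition.
Compound 2 `O=C(O)Cc1sc(C(c2ccc(F)cc2)c2ccc(F)cc2)nc1-c1cn[nH]c1` gives 220 nM in this assay.
Compound 3 `O=C(O)Cc1sc(C(c2ccc(F)cc2)c2ccc(F)cc2)nc1-c1ccnc(Cl)c1` gives 39 nM in this assay.

Compound 3 holds the lowest of the two numbers measured; the nearest is compound 2, through the step of a 5.6-fold lower number from compound 2 to compound 3 (0.75 log units; beyond the scatter). Compound 4 `O=C(O)Cc1sc(C(c2ccc(F)cc2)c2ccc(F)cc2)nc1-c1ccc(Cl)cc1` differs from compound 3 at the same ring: 4-chlorophenyl in place of 2-chloropyridin-4-yl on an aromatic carbon. Within the data shown here, two measured steps touch this position. The step of an at least 2500-fold lower number from compound 1 to compound 3 (3.40 log units; beyond the scatter) was large, and the step of a 5.6-fold lower number from compound 2 to compound 3 (0.75 log units; beyond the scatter) was modest. Among the measured compounds shown here, neither, however, swaps a ring nitrogen for a ring carbon while keeping the chlorine, so no measured step speaks directly to this change. The step of a 1.2-fold higher number from compound 3 to compound 4 (0.06 log units; within the scatter) is therefore expected to stay within the usual scatter. Compound 4 is estimated at 45 nM in this assay, with a range from 12 nM to 170 nM.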

Compound 4, half-maximal inhibitory concentration: 180 nM
The estimate for compound 4 lay 4.0-fold (0.60 log units) below the measured number, outside the stated range (above it).
By their numbers in this assay, from the lowest: compound 3; then compounds 4 and 2 (each within the scatter of the next). At a limit, above all of these: compound 1.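

Among these compounds, with the chlorine kept, swapping only the ring nitrogen for a ring carbon gives a 4.6-fold higher number from compound 3 to compound 4 (0.66 log units; beyond the scatter), so this single atom matters here, something no earlier step could isolate. Replacing 1H-pyrazol-4-yl with 4-chlorophenyl gives a 1.2-fold lower number from compound 2 to compound 4 (0.09 log units; within the scatter), so these two groups cannot be told apart on this read-out. The value of compound 1 is a limit, which makes an at least 550-fold lower number from compound 1 to compound 4 (2.74 log units; beyond the scatter) only a bound: the limit of > 100000 nM in this assay, at which 1 of the 4 values shown sits.

Still open, going by these compounds, is whether the ring nitrogen gives the same gain without the chlorine. A plain pyridin-4-yl group, or a 2-aminopyridin-4-yl group, would test this.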